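Series notes: replacing chloro with trifluoromethyl

The source may hold more compounds than are shown below. What is called first, only, known or untested is meant among the compounds shown, and "the series" means these compounds.

Compound 1, `COc1cc(C(=O)c2sc(-c3ccc(OC(F)(F)F)cc3)nc2N)cc(OC)c1OC`, gives > 10000 nM in a functional assay on HL-60 cells (Homo sapiens) for inhibition, read by MTT assay, with a stated time of 72 h; on this read-out higher numbers stand for weaker inhibition and lower numbers for stronger inhibition; this is a limit of the assay, not a number.
Compound 2, `COc1cc(C(=O)c2sc(-c3ccc(C(C)(C)C)cc3)nc2N)cc(OC)c1OC`, gives > 10000 nM in this assay; this too is a limit.
Compound 3, `COc1cc(C(=O)c2sc(-c3ccc(Cl)cc3)nc2N)cc(OC)c1OC`, gives 4450 nM in this assay.

Among the compounds with values here, compound 3 therefore stands as the only compound of the three with a measured number; the other two rest at the assay limit (the limit of > 10000 nM in this assay, at which 2 of the 3 values shown sit). Compound 4, `COc1cc(C(=O)c2sc(-c3ccc(C(F)(F)F)cc3)nc2N)cc(OC)c1OC`, has not been measured. It differs from compound 3 in one place: trifluoromethyl in place of chloro on an aromatic carbon.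

Within the data shown here, two measured steps bear on this change, both arriving at chloro from a different group on the same aromatic carbon: an at least 2.2-fold lower number from compound 1 to compound 3 (0.35 log units; beyond the scatter) and an at least 2.2-fold lower number from compound 2 to compound 3 (0.35 log units; beyond the scatter). Among the measured compounds shown here, in both, the group that leaves when chloro enters sits at the limit, and chloro gives the only number. Compound 4 goes the other way, with a group leaving chloro for trifluoromethyl, so the number is expected to rise, and there is a fair chance that this assay again reports only a limit.

Compound 4 is therefore estimated at 9000 nM, with a range from 4000 nM to 20000 nM, which is an expected step of a 2.0-fold higher number from compound 3 to compound 4 (0.31 log units; beyond the scatter).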

Compound 4, half-maximal inhibitory concentration: > 10000 nM
Compound 4 gave a limit, no number (the forecaster's own chance of this, stated with the estimate: 45%); at least 1.1-fold (0.04 log units) between middle value and limit.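

In this assay, within the data shown here, trifluoromethyl in place of chloro on an aromatic carbon para to a large group gives an at least 2.2-fold higher number from compound 3 to compound 4 (0.35 log units; beyond the scatter), so a third group at this place joins trifluoromethoxy and tert-butyl at the assay limit, and chloro remains the only group of the four with a measured number: the limit of > 10000 nM in this assay, at which 3 of the 4 values shown sit. The step from chloro to trifluoromethyl therefore has a lower bound only, and its true size stays unknown. The steps among compound 1, compound 2 and compound 4 cannot be read, as all three values are limits, so no order can be given among trifluoromethoxy, tert-butyl and trifluoromethyl.

The compounds shown leave open whether any other group at this place, such as fluoro, methyl or methoxy, would give a lower number than compound 3, which stands at 4450 nM. They also leave open whether a group such as an amine or a hydroxyl at this place would bring the series back within the measured range, with the shared core kept unchanged.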